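The source may report more compounds than this note shows. Statements on the series, on what has been measured and on what is new or still open speak of the compounds shown alone.

Compound 2 is `CC(C)C(NC(=O)NO)C(=O)NC1CCCCC1`. In a functional assay on MIA PaCa-2 cells (Homo sapiens) for inhibition (a higher number here means a weaker inhibitor, a lower number a stronger inhibitor), compound 2 reaches only the limit of the assay, > 100000 nM. Compound 1, `CCC(C)C(NC(=O)n1nnc2ccccc21)C(=O)NCc1ccccc1`, likewise gives in this assay only the limit > 100000 nM. Compound 3, `CCC(C)C(NC(=O)NO)C(=O)NC1CCCCC1`, also stops at the limit in this assay, > 100000 nM. The step that the two limits leave unreadable from compound 2 to compound 3 therefore cannot be read, since (the limit of > 100000 nM in this assay, at which 3 of the 3 values shown sit). Compound 4 is `CC(C)C(NC(=O)NO)C(=O)NC1CCCC1`, and it differs from compound 2 by cyclopentyl in place of cyclohexyl on an amide-type nitrogen. Among the compounds with values here, no measured step reports with a readable size on a change at this position, and every value seen so far sits at the limit. A step that the limit leaves unreadable from compound 2 to compound 4 is expected, meaning no change that can be read. Compound 4 is thus estimated at 200000 nM, within a range from 100000 nM to 1000000 nM, most likely again reported only as a limit.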

Compound 4, half-maximal inhibitory concentration: > 100000 nM
Compound 4: no number, only a limit; the forecaster's own chance of this, stated with the estimate: 90%; the middle value does not contradict the limit.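

Compound 4, like compound 2, stops at a limit, so the step between them cannot be read: the limit of > 100000 nM in this assay, at which 4 of the 4 values shown sit. The compounds shown leave open which structural change, if any, would give a readable number.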